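Working notes: benzimidazole-type series, aromatic substituent swap

The source may report more compounds than this note shows. Statements on the series, on what has been measured and on what is new or still open speak of the compounds shown alone.

Measured so far:
- compound 1, `CS(=O)(=O)Nc1ccc2nc(CN3CCC(Cc4ccccc4)CC3)[nH]c2c1`: 1500 nM
- compound 2, `N#Cc1ccc2[nH]c(Cc3ccc(Oc4ccccc4)cc3)nc2c1`: 3400 nM
- compound 3, `Oc1cccc2[nH]c(Cc3ccc(Oc4ccccc4)cc3)nc12`: 5500 nM

All three numbers come from an assay on membranes from brain for binding affinity to Adrenergic receptor alpha-1 (Rattus norvegicus); on this read-out higher numbers stand for weaker inhibition and lower numbers for stronger inhibition. Compound 2 gives 3400 nM, and compound 3 gives 5500 nM; these two values lie within the scatter of each other, so no order is read between them. Compound 1 gives 1500 nM, a lower number, and its gap to compound 2 is beyond the scatter. Compound 1 differs from compound 2 in more than one place, so its value shows only where it lands, not what any single change does.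

Compound 4, `CN(c1ccc2[nH]c(Cc3ccc(Oc4ccccc4)cc3)nc2c1)S(C)(=O)=O`, has not yet been measured. Against compound 2 the difference is methyl(methylsulfonyl)amino in place of cyano on an aromatic carbon of a six-membered aromatic ring of carbon only, part of a fused system of two rings. Among the measured compounds shown here, no pair of measured compounds isolates this change, so the expectation rests on the spread of the three numbers alone.

For compound 4 the expected value in this assay is 2500 nM, with a range from 800 nM to 8000 nM. The step that this estimate implies, a 1.4-fold lower number from compound 2 to compound 4 (0.13 log units; within the scatter), is expected to stay within the scatter, with no clear direction.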

Compound 4, half-maximal inhibitory concentration: 2000 nM
Compound 4: the middle estimate sits 1.3-fold (0.10 log units) above what was measured, within the range that was stated.
By their numbers in this assay, from the lowest: compounds 1, 4, 2 and 3 (each within the scatter of the next, the first and the last beyond it).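

In this assay, among the compounds shown here, the swap of cyano for methyl(methylsulfonyl)amino on an aromatic carbon of a six-membered aromatic ring of carbon only gives a 1.7-fold lower number from compound 2 to compound 4 (0.23 log units; within the scatter) and so provides the first reading of a change in one place. This aromatic carbon therefore carries either group, a 2-heavy-atom cyano with a triple bond or a 6-heavy-atom methyl(methylsulfonyl)amino with two double bonds and one more hydrogen-bond acceptor, with no order to be read between the two numbers. No measurement shown here explains why the step stays within the scatter.

Going by these compounds, one step at one position sets no trend, so it remains open whether an amine or a carboxylic acid on the same aromatic carbon would stay within the scatter of these two compounds or move clearly away from them. Also open, on these data alone, is what removing the methyl from the nitrogen of methyl(methylsulfonyl)amino would do on the core of compound 4, since compound 1 carries the unmethylated group only together with a different side chain.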